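The source may hold more compounds than are shown below. What is called first, only, known or untested is meant among the compounds shown, and "the series" means these compounds.

Working notes on a series built on the core of compound 1 `CCCCCN(CCCCC)C(=O)N1CCN(C(=O)N(c2ccccc2)c2ccccc2)[C@H](C(=O)O)C1`. In an assay for inhibition of Type-2 angiotensin II receptor (Rattus norvegicus) (on this read-out higher numbers stand for weaker inhibition and lower numbers for stronger inhibition), compound 1 gives 1.4 nM. Compound 2 `CCCCCN(CCCCC)C(=O)N1CCN(C(=O)N(c2ccccc2)c2cccc(Br)c2)[C@H](C(=O)O)C1` carries a bromo group on one of the phenyl rings; in this assay compound 2 gives 0.6 nM. The step from hydrogen to bromo at that position reads a 2.3-fold lower number from compound 1 to compound 2 (0.37 log units; beyond the scatter). Among the compounds with values here, compound 2 therefore holds the lowest of the two numbers measured so far, with compound 1 the nearest.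

The next compound is compound 3 `CCCCCN(CCCCC)C(=O)N1CCN(C(=O)N(c2ccccc2)c2cccc(C)c2)[C@H](C(=O)O)C1`. The change from compound 2 is methyl in place of bromo on an aromatic carbon. Within the data shown here, only one measured step bears on this position, a 2.3-fold lower number from compound 1 to compound 2 (0.37 log units; beyond the scatter), which shows that a substituent there is tolerated and lowers the number modestly. Among the measured compounds shown here, no measured step shows methyl at this position, so whether methyl matches bromo is unknown. The expectation is that the step from compound 2 to compound 3 comes out as a 1.5-fold higher number from compound 2 to compound 3 (0.18 log units; within the scatter), small and, if anything, towards a higher number, compound 3 staying near the two measured numbers. For compound 3 the estimate in this assay is 0.9 nM, with a range from 0.4 nM to 2 nM.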

Compound 3, half-maximal inhibitory concentration: 0.7 nM
Estimate against measurement, compound 3: 1.3-fold (0.11 log units) above, and the stated range covers the measured number.
By their numbers in this assay, from the lowest: compounds 2, 3 and 1 (each within the scatter of the next, the first and the last beyond it).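

In this assay, the change from 3-bromophenyl to 3-methylphenyl gives a 1.2-fold higher number from compound 2 to compound 3 (0.07 log units; within the scatter), so at this position the two groups cannot be told apart, and a carbon group of one heavy atom reads like the bromine that it replaces. The hydrogen-to-methyl change gives a 2.0-fold lower number from compound 1 to compound 3 (0.30 log units; within the scatter), which leaves compound 3 unseparated from compound 1, whereas the hydrogen-to-bromo step was the only one so far to lie beyond the scatter; the methyl compound therefore sits within the scatter of both neighbours, and the three numbers do not support a ranking of methyl against either hydrogen or bromo. No measurement available here accounts for these numbers or explains how either group acts at this position.

From the compounds shown here alone, whether a larger or differently built group at this position, such as methoxy, an amine, a carboxylic acid or a longer chain such as propyl, stays within the same narrow band remains open. Also open, going by these compounds, is whether bromo and methyl read alike when the two pentyl chains on the shared core give way to shorter chains such as butyl.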